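Swapping the piperazine substituent in compound 4

A few compounds are considered here, and "the series" means these few. Any claim that something is new, unique, unknown or untested is made for them only; others in the source may bear on it.

Three compounds share a core and differ only in the group hanging from an amide. Compound 1 `Cn1c(-c2ccc(NC(=O)CSc3nc4ccccc4o3)cc2)nc(-c2ccccc2)c1-c1ccccc1` carries a benzoxazolylsulfanyl group and gives 18.7% in a functional assay on MCF7 cells (Homo sapiens) for cytotoxicity, read by MTT assay, with a stated time of 24 h, tested at 0.64 ug/mL; on this read-out higher numbers stand for a stronger effect at the one concentration tested and lower numbers for a weaker effect. Compound 2 `Cc1nnc(SCC(=O)Nc2ccc(-c3nc(-c4ccccc4)c(-c4ccccc4)n3C)cc2)s1` gives 35.1% in this assay, so that a number 16.4 percentage points higher from compound 1 to compound 2 (beyond the scatter). Compound 3 `CN(C)/C=C/N1CCN(CC(=O)Nc2ccc(-c3nc(-c4ccccc4)c(-c4ccccc4)n3C)cc2)CC1` gives 1.2% in this assay, the lowest of the three numbers: a number 17.5 percentage points lower from compound 1 to compound 3 (beyond the scatter), and a number 33.9 percentage points lower from compound 2 to compound 3 (beyond the scatter). Both steps into compound 3 replaced a sulfur-linked heteroaromatic ring by the piperazine bearing the dimethylaminoethenyl group, and both lowered the read-out.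

Compound 4 `Cc1ccc(CN2CCN(CC(=O)Nc3ccc(-c4nc(-c5ccccc5)c(-c5ccccc5)n4C)cc3)CC2)cc1` keeps that piperazine and changes only what sits on its ring nitrogen: 4-methylbenzyl in place of 2-(dimethylamino)ethenyl on an amine nitrogen in a ring. Among the compounds with values here, no measured step touches this position; the two steps that end at compound 3 concern the exchange of the whole group on the chain carbon, not a change on the piperazine nitrogen itself. Within the data shown here, they show only that compound 3 starts from a low number, leaving little room for a further fall. The expectation for compound 4 is therefore a small step, most likely upward but possibly within the scatter, a number 7.8 percentage points higher from compound 3 to compound 4 (within the scatter). Compound 4 is estimated at 9% in this assay, within a range from 0% to 25%.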

Compound 4, a percentage reported as activity, at one concentration (the size of the read-out at that concentration, not a potency): 9.4%
Compound 4: middle estimate off by 0.4 percentage points, on the low side, within the range that was stated.
By their numbers in this assay, from the lowest: compounds 3, 4 and 1 (each within the scatter of the next, the first and the last beyond it); then compound 2.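

Within the data shown here, this is the first measured change on an amine nitrogen in a ring of this six-membered non-aromatic ring: 4-methylbenzyl in place of 2-(dimethylamino)ethenyl gives a number 8.2 percentage points higher from compound 3 to compound 4 (within the scatter) in this assay, so the two compounds cannot be told apart on this read-out. The exchange is a sizeable one, since a group of 8 heavy atoms with a six-membered aromatic ring of carbon only and no hydrogen-bond acceptor takes the place of a group of 5 heavy atoms with no ring, a double bond and 1 hydrogen-bond acceptor, yet the result shows no effect that stands clear of the usual scatter. No independent measurement on either group is available to bear on this result.

As far as these compounds go, what a plain methyl, an unsubstituted benzyl or a benzyl with chlorine in place of the methyl would give on this nitrogen remains open. From the compounds shown here alone, it is also open whether a chain ending in an amine or in a carboxylic acid, placed on the same nitrogen, would give a read-out beyond the scatter from that of compound 3 or compound 4.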